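Swapping phenyl for cyclohexyl on the aryl ether oxygen

The source may hold more compounds than are shown below. What is called first, only, known or untested is meant among the compounds shown, and "the series" means these compounds.

Two compounds carry the same core bearing a serine phosphate head. Compound 1 `N[C@@H](COP(=O)(O)OCCCOC(=O)CCc1ccccc1OCCCCCCOc1ccccc1)C(=O)O` gives 0.071 in an assay on cells for activation of probable G-protein coupled receptor 34 (Mus musculus), with a stated time of 1 h; a higher number here means a larger maximal response, a lower number a smaller maximal response. Compound 2 `N[C@@H](COP(=O)(O)OCCCOC(=O)CCc1ccccc1OCc1cccc(Oc2ccccc2)c1)C(=O)O` gives 0.48 in this assay, the higher of the two numbers, standing above compound 1 by a gap beyond the usual scatter. Compound 3 `N[C@@H](COP(=O)(O)OCCCOC(=O)CCc1ccccc1OCc1cccc(OC2CCCCC2)c1)C(=O)O` differs from compound 2 in one place: cyclohexyl in place of phenyl on an oxygen on an aromatic ring — phenoxy becomes cyclohexyloxy. Within the data shown here, no measured pair shows this change, so only a modest step, perhaps a small drop or none beyond the scatter, is expected a number 0.080 lower from compound 2 to compound 3 (within the scatter). Compound 3 is estimated at 0.4, within 0.15 to 0.65.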

Compound 3, intrinsic activity: the largest response reached, as a fraction of the reference agonist's: 0.11
Compound 3: the middle estimate sits 0.29 above what was measured; the measured number lies below the stated range.
By their numbers in this assay, from the lowest: compounds 1 and 3 (each within the scatter of the next); then compound 2.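

Cyclohexyl in place of phenyl on an oxygen on an aromatic ring gives a number 0.37 lower from compound 2 to compound 3 (beyond the scatter) in this assay and so shows that the maximal response is sensitive to which ring stands at this position. The two groups match in heavy atoms, hydrogen-bond donors, hydrogen-bond acceptors and net charge, and differ in that one ring is aromatic and the other is not. Nothing available accounts for the size of this step.

Going by these compounds, whether a pyridyl ring or a cyclopentyl ring on this oxygen would keep the response of compound 2 stays open.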